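Substituent change on a shared core: from compound 3 to compound 4

The source may report more compounds than this note shows. Statements on the series, on what has been measured and on what is new or still open speak of the compounds shown alone.

The study measures growth inhibition in a functional assay on A549 cells (Homo sapiens) for inhibition, read by CCK-8 assay, with a stated time of 48 h (on this read-out lower numbers stand for stronger inhibition and higher numbers for weaker inhibition), across a small set of compounds built on one shared core. Compound 1 `COc1cc(-c2ccnc3c(-c4ccc(C)cc4)cnn23)cc(OC)c1OC` gives a limit of the assay, > 10000 nM, and not a number. Compound 2 `COc1cc(-c2cc3nccc(-c4c[nH]c5ccccc45)n3n2)cc(OC)c1OC` likewise gives only a limit, > 10000 nM. For the measured compounds named here, compound 3 `COc1ccc(-c2cc3nccc(-c4cc(OC)c(OC)c(OC)c4)n3n2)cc1F` is the one compound with a measured number, 545 nM in this assay, so it stands alone among the values shown; the other two values sit at the limit of > 10000 nM in this assay, at which 2 of the 3 values shown sit, and cannot be ranked against it.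

Compound 4 `COc1cc(-c2ccnc3cc(-c4ccc(C)c(C)c4)nn23)cc(OC)c1OC` is not yet measured. It differs from compound 3 in one place: 3,4-dimethylphenyl in place of 3-fluoro-4-methoxyphenyl on an aromatic carbon. Going by the values given here, with no measured step between two compounds to lean on, the size of this change in this assay can only be expected, not inferred. The account expects a modest loss, a step of a 2.8-fold higher number from compound 3 to compound 4 (0.44 log units; beyond the scatter) beyond the usual scatter. Compound 4 is therefore estimated at 1500 nM, within a range from 400 nM to 6000 nM.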

Compound 4, half-maximal inhibitory concentration: 272 nM
Beside the measured number, compound 4's estimate is 5.5-fold (0.74 log units) above it; the measured number lies below the stated range.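

In this assay, for the compounds shown here, putting 3,4-dimethylphenyl in place of 3-fluoro-4-methoxyphenyl on an aromatic carbon of the five-membered aromatic ring gives a 2.0-fold lower number from compound 3 to compound 4 (0.30 log units; within the scatter) and this is the first step in the set that can be read as a comparison of two numbers. At this position, then, a group of carbon only, without the oxygen and fluorine of the group it replaces, keeps the number within the scatter, so neither compound can be ranked over the other. Steps to the remaining compounds cannot be read, since their values are limits and not numbers: the limit of > 10000 nM in this assay, at which 2 of the 4 values shown sit.

Going by these compounds, the two comparable compounds carry only substituted phenyl groups at this position, so what the number does with an amine, a carboxylic acid or a longer chain there stays open. Whether a phenyl group with a single methyl behaves like these two also remains unanswered.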